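This account rests on a few compounds, and the source may have more. Where it says the series, first, only, none or still open, it means among the compounds named here.

Working notes on the thiazole amide series in a functional assay for antagonist activity at thyroid hormone receptor alpha (Homo sapiens), read by fluorescence polarization; a lower number here means a stronger inhibitor, a higher number a weaker inhibitor.

Compound 3 `CC1Cc2ccccc2N1C(=O)c1sc(-c2ccc(S(C)(=O)=O)c([N+](=O)[O-])c2)nc1C(F)(F)F` gives 1100 nM in this assay. For the measured compounds named here, it stands second highest of the three numbers so far: its nearest neighbour is compound 2 `CN(Cc1cccc(F)c1)C(=O)c1sc(-c2ccc(S(C)(=O)=O)c([N+](=O)[O-])c2)nc1C(F)(F)F` with 1000 nM, the two lying within the scatter of each other, while compound 1 `CN(Cc1cccc(F)c1)C(=O)c1cnc(-c2ccc(S(C)(=O)=O)c([N+](=O)[O-])c2)s1` with 3200 nM sits furthest away, beyond the scatter. The step from compound 1 to compound 2, trifluoromethyl in place of hydrogen on an aromatic carbon, gave a 3.2-fold lower number from compound 1 to compound 2 (0.51 log units; beyond the scatter); the step from compound 2 to compound 3 gave a 1.1-fold higher number from compound 2 to compound 3 (0.04 log units; within the scatter).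

Compound 4 `CN(Cc1ccccc1)C(=O)c1sc(-c2ccc(S(C)(=O)=O)c([N+](=O)[O-])c2)nc1C(F)(F)F` is not yet measured. It differs from compound 3 by benzyl(methyl)amino in place of 2-methyl-2,3-dihydro-1H-indol-1-yl on a carbonyl carbon. Going by the values given here, the only measured step that bears on this change is the one from compound 2 to compound 3, which swapped the same amide substituent in the opposite direction and stayed within the scatter. Compound 4 also carries benzyl(methyl)amino where compound 2 carries (3-fluorobenzyl)(methyl)amino, so compound 2 offers a second anchor close in structure. On that basis the step from compound 3 to compound 4 is expected to be no change at the digits printed from compound 3 to compound 4 (within the scatter), no change beyond the scatter. Compound 4 is therefore estimated at 1100 nM in this assay, with a range from 500 nM to 2500 nM.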

Compound 4, half-maximal inhibitory concentration: 460 nM
The estimate for compound 4 lay 2.4-fold (0.38 log units) above the measured number, and the stated range ends above it.
By their numbers in this assay, from the lowest: compound 4; then compounds 2 and 3 (each within the scatter of the next); then compound 1.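

On the carbonyl carbon, the amide substituent now makes a difference in this assay: benzyl(methyl)amino in place of 2-methyl-2,3-dihydro-1H-indol-1-yl gives a 2.4-fold lower number from compound 3 to compound 4 (0.38 log units; beyond the scatter), whereas the earlier swap from (3-fluorobenzyl)(methyl)amino to the same 2-methyl-2,3-dihydro-1H-indol-1-yl group gave only a 1.1-fold higher number from compound 2 to compound 3 (0.04 log units; within the scatter) and did not separate the two amides. For the compounds shown here, the result also shows that a single aromatic substituent on the benzyl group matters, since hydrogen in place of fluoro gives a 2.2-fold lower number from compound 2 to compound 4 (0.34 log units; beyond the scatter), a change that the earlier compounds did not test. No supporting data are available to explain either step.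

It remains open whether the lower number of compound 4 depends on the trifluoromethyl group of the shared core, since the pair that would test this, benzyl(methyl)amino on the core of compound 1, is not among the compounds shown. Also open, as far as these compounds go, is how a longer chain in place of the methyl of benzyl(methyl)amino, or a carboxylic acid or an amine on its aromatic ring, would read.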